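Bromo for hydroxy at the edge of the core

The source may hold more compounds than are shown below. What is called first, only, known or untested is meant among the compounds shown, and "the series" means these compounds.

Compound 1 `Cc1ccc(CS/C(=C/c2ccc(O)cc2)C(=O)c2ccc(Cl)cc2)cc1` and compound 2 `O=C(O)c1ccc(C(=O)/C(=C\c2ccc(Br)c([N+](=O)[O-])c2)SCc2ccc(Cl)cc2Cl)cc1` were both tested in a functional assay on DU-145 cells (Homo sapiens) for inhibition, read by trypan blue exclusion, with a stated time of 96 h; a lower number here means a stronger inhibitor of growth, a higher number a weaker inhibitor of growth. Compound 1 gives 10000 nM, the highest number of the two, while compound 2 gives 1000 nM, a gap that lies beyond the scatter. Going by the values given here, no single-change step links these two, since they differ in several places at once, so their values only show that compound 2 is the stronger inhibitor of growth.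

The next compound, compound 3 `Cc1ccc(CS/C(=C/c2ccc(Br)cc2)C(=O)c2ccc(Cl)cc2)cc1`, is not yet measured in this assay. It differs from compound 1 in one place: bromo in place of hydroxy on an aromatic carbon. The change sits on an aromatic carbon of a six-membered aromatic ring of carbon only, para to a large group, so that the 4-hydroxyphenyl of compound 1 becomes a 4-bromophenyl.

Among the compounds with values here, with no measured step of this kind to lean on, the expectation for compound 3 rests on compound 1 alone, and the expected shift a 2.0-fold lower number from compound 1 to compound 3 (0.30 log units; within the scatter) is modest, leaning toward a lower number. Compound 3 is therefore estimated at 5000 nM, within a range from 1500 nM to 15000 nM.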

Compound 3, concentration for 50% growth inhibition: 10000 nM
The estimate for compound 3 lay 2.0-fold (0.30 log units) below the measured number; measured number inside the range.
By their numbers in this assay, from the lowest: compound 2; then compounds 1 and 3 (each within the scatter of the next).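

In this assay, going by these compounds alone, putting bromo on this aromatic carbon gives no change at the digits printed from compound 1 to compound 3 (within the scatter), the first reading of a single change. The hydroxy leaves with its hydrogen-bond donor and acceptor, and bromo, which counts neither, takes its place, yet the pair cannot be told apart in this assay, so in the setting of compound 1 the 4-hydroxyphenyl and the 4-bromophenyl read alike. Nothing available here explains why these two compounds read alike.

As far as these compounds go, whether an amine, a methoxy group or a carboxylic acid on this same aromatic carbon would also leave the reading where it stands remains open, as does the effect of a longer chain there. Also open, from the compounds shown here alone, is whether the same exchange would read alike on a more active background such as compound 2 at 1000 nM in this assay, or whether the gap between that compound and the other two arises from one of its several other differences.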